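The source may report more compounds than this note shows. Statements on the series, on what has been measured and on what is new or still open speak of the compounds shown alone.

Compound 3 `COc1cc(/C=C2/C(=O)N(c3ccc(Cl)cc3)N=C2C)ccc1OC(C)=O` gives 1940 nM in an assay for inhibition of Alpha amylase (Homo sapiens), with a stated time of 10 min; on this read-out higher numbers stand for weaker inhibition and lower numbers for stronger inhibition. Compound 1 `COc1ccc(/C=C2/C(=O)N(c3ccc(Cl)cc3)N=C2C)cc1OC` gives 2030 nM and compound 2 `COc1cc(/C=C2/C(=O)N(c3ccc(Cl)cc3)N=C2C)cc(OC)c1Br` gives 1680 nM; both sit within the scatter of compound 3, so the three numbers are not distinguished. For the measured compounds named here, the only measured step at the oxygen on the aromatic ring, a 1.0-fold lower number from compound 1 to compound 3 (0.02 log units; within the scatter), stayed within the scatter. Compound 4 `COc1cc(/C=C2/C(=O)N(c3ccc(Cl)cc3)N=C2C)ccc1OCc1ccccc1` carries benzyl in place of acetyl on an oxygen on an aromatic ring. Nothing measured tells how a benzyl behaves at this oxygen; only the acetyl-for-methyl step is known, and it was flat. The expected step, a 1.2-fold lower number from compound 3 to compound 4 (0.08 log units; within the scatter), is therefore none beyond the scatter, with a wide range. Compound 4 is estimated at 1600 nM, between 600 nM and 4500 nM.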

Compound 4, half-maximal inhibitory concentration: 2330 nM
For compound 4 the middle estimate is 1.5-fold (0.16 log units) below the measured one; low and high end bracket the measured number.
By their numbers in this assay, from the lowest: compounds 2, 3, 1 and 4 (each within the scatter of the next).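

Benzyl on this oxygen brings a six-membered aromatic ring, yet the number does not move beyond the scatter in this assay (a 1.2-fold higher number from compound 3 to compound 4 (0.08 log units; within the scatter)) or against the methyl ether (a 1.1-fold higher number from compound 1 to compound 4 (0.06 log units; within the scatter)). The flat reading at this oxygen, so far shown only for acetyl and methyl, therefore extends to a substituent carrying an aromatic ring. No measurement on hand accounts for this flat reading.

Still open, as far as these compounds go, is whether a group of another kind on this oxygen, such as an amine or a carboxylic acid, would shift the number beyond the scatter.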